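Removing one bromine from a tribrominated cyclopentenedione core

A few compounds are considered here, and "the series" means these few. Any claim that something is new, unique, unknown or untested is made for them only; others in the source may bear on it.

Compound 1 has the structure `COC(=O)C1=C(c2cc(Br)c(O)c(Br)c2)C(=O)[C@](c2ccc(O)c(Br)c2)(c2cc(Br)c(O)c(Br)c2)C1=O`. In a functional assay on K562 cells (Homo sapiens) for cytotoxicity, read by sulforhodamine B assay, with a stated time of 72 h (on this read-out higher numbers stand for weaker inhibition and lower numbers for stronger inhibition), compound 1 gives > 10000 nM, which is a limit of the assay rather than a measured number. Compound 2, with the structure `O=C(O)C1=C(c2ccc(O)c(Br)c2)C(=O)C(c2cc(Br)c(O)c(Br)c2)(c2cc(Br)c(O)c(Br)c2)C1=O`, carries a free carboxylic acid where compound 1 carries a methyl ester. In this assay compound 2 likewise gives only the limit > 10000 nM. Compound 1 therefore stands at the limit of > 10000 nM in this assay, at which 2 of the 2 values shown sit, and nothing in the numbers sets it apart from compound 2.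

Compound 3, not yet measured, has the structure `COC(=O)C1=C(c2ccc(O)c(Br)c2)C(=O)[C@](c2ccc(O)c(Br)c2)(c2cc(Br)c(O)c(Br)c2)C1=O`. It differs from compound 1 in one place: hydrogen in place of bromo on an aromatic carbon, so one 3,5-dibromo-4-hydroxyphenyl ring becomes a 3-bromo-4-hydroxyphenyl ring. For the measured compounds named here, no measured pair in this set shows what such a change does. The step that the limit leaves unreadable from compound 1 to compound 3 is expected to lie within the usual scatter, with no clear direction. Compound 3 is accordingly expected to give about 15000 nM, within a range from 5000 nM to 50000 nM, most likely again reported only as a limit.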

Compound 3, half-maximal inhibitory concentration: > 10000 nM
Compound 3 ended at the assay's limit (the forecaster's own chance of this, stated with the estimate: 80%); the middle value lies beyond the limit too.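

In this assay compound 3 gives > 10000 nM and this is a limit of the assay, not a number. For the compounds shown here, compound 1 also sits at a limit, so no step between compound 1 and compound 3 can be read. The compounds shown leave open whether going from 3,5-dibromo-4-hydroxyphenyl to 3-bromo-4-hydroxyphenyl changes cytotoxicity at all.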